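The compounds below may be only part of what the source reports. "The series", "measured", "known", "first", "only" and "open" are said of these compounds alone.

Compound 2 `CCOc1cc(NC(=O)CCCCCCC(=O)Nc2cc(-c3ccc(C)s3)ccc2N)cc2c1OCC([N+](=O)[O-])=C2` and compound 1 `CCOc1cc(NC(=O)CCCCCCC(=O)Nc2ccccc2N)cc2c1OCC([N+](=O)[O-])=C2` share a core and differ in one place: hydrogen in place of 5-methylthiophen-2-yl on an aromatic carbon. In a functional assay on HeLa cells (Homo sapiens) for antiproliferative activity, read by MTT assay, with a stated time of 48 h (a lower number here means a stronger inhibitor of growth, a higher number a weaker inhibitor of growth), compound 2 gives only a limit of the assay, > 20000 nM. In this assay compound 1 likewise gives only a limit, > 20000 nM. The step that the two limits leave unreadable from compound 2 to compound 1 therefore cannot be read, since (the limit of > 20000 nM in this assay, at which 3 of the 3 values shown sit). Compound 3 `CCOc1cc(NC(=O)CCCCCC(=O)Nc2cc(-c3ccc(C)s3)ccc2N)cc2c1OCC([N+](=O)[O-])=C2` carries the same 5-methylthiophen-2-yl group on a core whose difference from the core of compound 2 is not broken down here. In this assay compound 3 gives only a limit, > 20000 nM. Compound 4 `CCOc1cc(NC(=O)CCCCCC(=O)Nc2ccccc2N)cc2c1OCC([N+](=O)[O-])=C2` is compound 3 with the same change: hydrogen in place of 5-methylthiophen-2-yl on an aromatic carbon. Because (the limit of > 20000 nM in this assay, at which 3 of the 3 values shown sit), compound 4 is expected to sit at the limit as well, which means an expected step that the limit leaves unreadable from compound 3 to compound 4. The estimate for compound 4 is 30000 nM, expected to fall between 15000 nM and 100000 nM.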

Compound 4, concentration for 50% growth inhibition: 14900 nM
Compound 4: the middle estimate sits 2.0-fold (0.30 log units) above what was measured; measured number below the stated range.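

In this assay, hydrogen in place of 5-methylthiophen-2-yl on the core of compound 3 gives an at least 1.3-fold lower number from compound 3 to compound 4 (0.12 log units; that floor lies within the scatter). The chain change, (2-aminophenyl)carbamoyl in place of ((2-aminophenyl)carbamoyl)methyl, gives an at least 1.3-fold lower number from compound 1 to compound 4 (0.12 log units; that floor lies within the scatter). The hydrogen change on the other core and every other step cannot be read, so the data do not show whether the change carries from one core to the other, because the values stop at a limit: the limit of > 20000 nM in this assay, at which 3 of the 4 values shown sit.

Still open, as far as these compounds go, is how an amine or a carboxylic acid in place of 5-methylthiophen-2-yl would behave on either core. From the compounds shown here alone, a shorter chain is equally open, as is whether any of these would give values that can be read on both cores.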